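Swapping an Aminophenylamino Group for Piperazine

The source may report more compounds than this note shows. Statements on the series, on what has been measured and on what is new or still open speak of the compounds shown alone.

Among the compounds with values here, compound 1 `Nc1ccc(Nc2c(C(=O)NCc3ccc(F)cc3)nc(Br)c3cccnc23)cc1` is the only member of this small set with a number attached to it. In a functional assay on SK-BR-3 cells (Homo sapiens) for cytotoxicity, read by MTT assay, with a stated time of 72 h (a higher number here means a weaker inhibitor, a lower number a stronger inhibitor), compound 1 gives 4000 nM. Compound 2 `CN(C)c1ccc(CNC(=O)c2nc(Br)c3cccnc3c2N[C@H]2CC[C@H](N)CC2)cc1` has in this assay only the entry "not determined" (no result reported), so compound 1 stands alone on the numbers shown. Compound 3 `O=C(NCc1ccc(F)cc1)c1nc(Br)c2cccnc2c1N1CCNCC1` has not yet been measured. It differs from compound 1 in one place: piperazin-1-yl in place of (4-aminophenyl)amino on an aromatic carbon. Within the data shown here, no step between two measured compounds is available to anchor the size of this change, so any expectation rests on the single value of compound 1 alone. The step from compound 1 to compound 3 is expected to be modest and toward weaker inhibition, on the order of a 1.5-fold higher number from compound 1 to compound 3 (0.18 log units; within the scatter). Compound 3 is accordingly expected to give roughly 6000 nM in this assay, within a range from 1500 nM to 25000 nM.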

Compound 3, half-maximal inhibitory concentration: 6000 nM
Estimate against measurement, compound 3: no gap at the digits printed; low and high end bracket the measured number.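

In this assay, piperazin-1-yl in place of (4-aminophenyl)amino on this aromatic carbon, para to the bromo group, gives a 1.5-fold higher number from compound 1 to compound 3 (0.18 log units; within the scatter). At this position, a six-membered aromatic ring of carbon only and a six-membered non-aromatic ring with 2 hetero atoms therefore cannot be told apart in this cell read-out, although the two groups also differ in heavy atoms and hydrogen-bond donors. No measurement shown offers an explanation for this result.

The compounds shown leave open whether this insensitivity extends to groups of other kinds at the same carbon, such as morpholin-4-yl, a plain amino group or a longer aminoalkyl chain. They also leave open whether any group here can move the value beyond the usual scatter.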